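Replacing the hydroxy group of compound 3

This account rests on a few compounds, and the source may have more. Where it says the series, first, only, none or still open, it means among the compounds named here.

Measured in a functional assay on HepG2 cells (Homo sapiens) for antiproliferative activity, read by sulforhodamine B assay, with a stated time of 48 h; on this read-out lower numbers stand for stronger inhibition and higher numbers for weaker inhibition:
compound 1 `COc1ccc(/C=C/C(=O)c2ccccc2-c2ccc(F)cc2)cc1`: 93 nM
compound 2 `COc1ccc(/C=C/C(=O)c2ccccc2-c2ccc(F)cc2)cc1OC`: 95 nM
compound 3 `COc1ccc(/C=C/C(=O)c2ccccc2-c2ccc(F)cc2)cc1O`: 23 nM
Not yet measured: compound 4 `COc1ccc(/C=C/C(=O)c2ccccc2-c2ccc(F)cc2)cc1B(O)O`

Of the three measured compounds, compound 3 has the lowest number, 23 nM, and its steps to both others lie beyond the scatter. Hydroxy in place of hydrogen gave a 4.0-fold lower number from compound 1 to compound 3 (0.61 log units; beyond the scatter). Hydrogen in place of methyl on an oxygen gave a 4.1-fold lower number from compound 2 to compound 3 (0.62 log units; beyond the scatter). Methoxy in place of hydrogen, by contrast, gave a 1.0-fold higher number from compound 1 to compound 2 (0.01 log units; within the scatter).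

The next change is a group of 3 heavy atoms (1 boron, 2 oxygen; no ring) in place of one oxygen atom, on an aromatic carbon. The new group stands on an aromatic carbon, ortho to a methoxy group and meta to a large group. For the measured compounds named here, no measured compound carries boron, so no measured step covers this change directly. The nearest guide is the modest step of a 4.0-fold lower number from compound 1 to compound 3 (0.61 log units; beyond the scatter), which marks what the hydroxy group is worth in this series. If that difference were lost entirely, compound 4 would be expected near compound 1, which gives 93 nM. If it were kept, compound 4 would be expected near compound 3. An outcome between the two is expected.

The expected step is a 1.7-fold higher number from compound 3 to compound 4 (0.24 log units; within the scatter). In this assay the estimate for compound 4 is 40 nM, with an expected range from 10 nM to 150 nM.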

Compound 4, half-maximal inhibitory concentration: 30 nM
Compound 4: middle estimate off by 1.3-fold (0.12 log units), on the high side; the range from low to high includes it.
By their numbers in this assay, from the lowest: compounds 3 and 4 (each within the scatter of the next); then compounds 1 and 2 (each within the scatter of the next).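

At this aromatic carbon, ortho to a methoxy group, the boron-bearing group of 3 heavy atoms served in place of hydroxy in this assay with no change beyond the scatter, giving a 1.3-fold higher number from compound 3 to compound 4 (0.12 log units; within the scatter) for the exchange. A low number at this position is therefore not unique to hydroxy, since the new group also stands apart from hydrogen, with a 3.1-fold lower number from compound 1 to compound 4 (0.49 log units; beyond the scatter) on that change, and from methoxy, with a 3.2-fold lower number from compound 2 to compound 4 (0.50 log units; beyond the scatter) on that change. Nothing measured here accounts for why hydroxy and the boron-bearing group behave alike at this position.

The compounds shown leave open whether other groups on this carbon, such as an amine or a carboxylic acid, would give numbers like those of compound 3 and compound 4, and whether the boron-bearing group would hold its place on a core without the fluorine. They also leave open whether the small step between hydroxy and the boron-bearing group would persist on cell lines other than those of this assay, as all four compounds are compared in that one setting.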